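The compounds below may be only part of what the source reports. "The series", "measured", "known", "first", "only" and "open" are said of these compounds alone.

Working notes on the core shared by compound 1 `COc1ccc2[nH]c3c(c2c1)CCNC31CCN(Cc2ccc([N+](=O)[O-])cc2F)CC1`, compound 2 `COc1ccc2[nH]c3c(c2c1)CCNC31CCN(Cc2ccc(Br)c(F)c2)CC1` and compound 3 `COc1ccc2[nH]c3c(c2c1)CCNC31CCN(Cc2cc(F)cc(F)c2)CC1`, which differ only in the aryl group on a saturated chain carbon bound to an amine nitrogen in a ring. In an assay on FRT cells for positive allosteric modulation of Cystic fibrosis transmembrane conductance regulator variant N1303K (Homo sapiens), in the presence of a further agent that is not named here (on this read-out higher numbers stand for an effect only at larger amounts of compound and lower numbers for an effect already at smaller amounts), compound 1 gives 5900 nM, compound 2 gives 1800 nM and compound 3 gives 11100 nM. Compound 1 thus stands second highest of the three numbers: the step of a 3.3-fold lower number from compound 1 to compound 2 (0.52 log units; beyond the scatter) is beyond the scatter, whereas the step of a 1.9-fold higher number from compound 1 to compound 3 (0.27 log units; within the scatter) stays within it, and the step of a 6.2-fold higher number from compound 2 to compound 3 (0.79 log units; beyond the scatter) is the widest spread in the set.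

Compound 4 `COc1ccc2[nH]c3c(c2c1)CCNC31CCN(Cc2ccccn2)CC1` is the next member to be measured. Its change from compound 1 is pyridin-2-yl in place of 2-fluoro-4-nitrophenyl on a saturated chain carbon bound to an amine nitrogen in a ring. Among the compounds with values here, all three measured steps swap one substituted benzene ring for another; none replaces the benzene ring with a heteroaromatic ring, so no measured step bears directly on this change. The measured steps only show that changing the aryl group moves the number by a modest amount in either direction. Within the data shown here, with no closer precedent, a step of about the size seen between compound 1 and compound 3, toward a higher number, is expected: a 1.5-fold higher number from compound 1 to compound 4 (0.18 log units; within the scatter). Compound 4 is therefore estimated at 9000 nM in this assay, with a range from 2500 nM to 30000 nM.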

Compound 4, half-maximal effective concentration: 11500 nM
Estimate against measurement, compound 4: 1.3-fold (0.11 log units) below; the measured number falls inside the stated range.
By their numbers in this assay, from the lowest: compound 2; then compounds 1, 3 and 4 (each within the scatter of the next).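

In this assay this position now carries a ring with a hetero atom, and the pyridin-2-yl group falls in with the 2-fluoro-4-nitrophenyl and 3,5-difluorophenyl groups, since a 1.9-fold higher number from compound 1 to compound 4 (0.29 log units; within the scatter) and a 1.0-fold higher number from compound 3 to compound 4 (0.02 log units; within the scatter) both stay within the scatter. The 4-bromo-3-fluorophenyl group alone stands apart, as a 6.4-fold higher number from compound 2 to compound 4 (0.81 log units; beyond the scatter) lies beyond the scatter, so the smaller number of compound 2 remains the only clear separation among the four aryl groups. No measurement at hand accounts for either the agreement among those three groups or the separation of compound 2.

The plain phenyl group and the pyridin-3-yl and pyridin-4-yl groups are absent from the compounds shown, which leaves open whether the ring nitrogen of compound 4 matters at all, and whether its place in the ring does. The 4-bromophenyl and 3-bromophenyl groups are also absent, so the bromine of compound 2 cannot yet be read apart from the fluorine on the same ring.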